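Half-Life Outlook for Compound 4

The compounds below may be only part of what the source reports. "The series", "measured", "known", "first", "only" and "open" are said of these compounds alone.

compound 1: `C/C(=C1/OC(=O)NC1=O)C(c1ccc(-c2ccc3cccc(F)c3c2)[nH]c1=O)C(C)C`, > 3 h
compound 2: `CC(C)/C(=C1\C(=O)NC(=O)N1C)c1ccc(-c2ccc3cccc(F)c3c2)[nH]c1=O`, > 3 h
compound 3: `CC(C)[C@@H](c1ccc(-c2ccc3cccc(F)c3c2)[nH]c1=O)[C@H]1OC(=O)NC1=O`, > 3 h

Of the compounds shown here, three sharing one core have been tested in an ADME assay on microsomes from liver (Homo sapiens) for metabolic stability; a higher number here means that the compound lasts longer, a lower number that the compound disappears faster. For compound 1 the value > 3 h is a limit of this assay, not a number. For compound 2 the result > 3 h is likewise a limit. For compound 3 the result > 3 h is a limit as well. Among the compounds with values here, compound 1 therefore stands where every measured compound stands, namely at the limit of > 3 h in this assay, at which 3 of the 3 values shown sit, and no step between measured compounds can be sized from these data.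

Compound 4 is `CC(C)C(c1ccc(-c2ccc3cccc(F)c3c2)[nH]c1=O)C1SC(=O)NC1=O`, not yet measured in this assay. It differs from compound 1 in one place: a group of 7 heavy atoms (3 carbon, 1 nitrogen, 2 oxygen, 1 sulfur; one five-membered non-aromatic ring with 2 hetero atoms) in place of a group of 9 heavy atoms (5 carbon, 1 nitrogen, 3 oxygen; one five-membered non-aromatic ring with 2 hetero atoms), on a saturated chain carbon bound to an aromatic carbon and a saturated chain carbon.

With all three known values sitting at the same limit, no direction for the change is indicated by the data. The step of a number no higher from compound 1 to compound 4 (the limit leaves the size open) is expected to stay within the usual scatter. For compound 4 the estimated half-life is 3 h, with a range from 1.5 h to 6 h, and the assay is expected most likely to report a limit again.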

Compound 4, half-life: 1.87 h
Compound 4: the middle estimate sits 1.6-fold (0.21 log units) above what was measured, within the range that was stated.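

Within the data shown here, at this position, on a saturated chain carbon bound to an aromatic carbon and a saturated chain carbon, 2,4-dioxo-1,3-thiazolidin-5-yl gives the only value in this assay that is a number and not a limit, and the change reads as an at least 1.6-fold lower number from compound 1 to compound 4 (0.20 log units; that floor lies within the scatter). On these data alone, for compound 1, > 3 h is a limit, so the full size of this step remains unknown. Compound 4 is thus the one compound shown that stands apart from the shared reading: the limit of > 3 h in this assay, at which 3 of the 4 values shown sit.

The data cannot separate the sulfur of the incoming ring from the other differences between the two groups as the source of the step. They also leave open how a carboxylic acid or an amine at this position would behave in this assay.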